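The compounds below may be only part of what the source reports. "The series", "measured", "known", "first", "only" and "open" are said of these compounds alone.

In a functional assay on MDA-MB-231 cells (Homo sapiens) for cytotoxicity, read by MTT assay, with a stated time of 72 h (a higher number here means a weaker inhibitor, a lower number a stronger inhibitor), compound 1 (`Nc1ccccc1NC(=O)c1ccc(NC(=S)NCc2ccc(Cl)nc2)cc1`) gives 42000 nM. For the measured compounds named here, the only other measured compound, compound 2 (`Nc1ccccc1NC(=O)c1ccc(CNC(=O)c2cc3cnccc3[nH]2)cc1`), gives 48000 nM. These two values lie within the scatter of each other, so compound 1 cannot be told apart from compound 2 on these numbers. The two compounds do not form a step that differs in one place, so the data contain no measured effect of any single structural change.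

Compound 3 (`Nc1ccccc1NC(=O)c1ccc(NC(=S)NCc2cccc(Cl)c2)cc1`) has not yet been measured in this assay. It differs from compound 1 in one place: 3-chlorophenyl in place of 6-chloropyridin-3-yl on a saturated chain carbon bound to an amide-type nitrogen. In words, 3-chlorophenyl stands in place of 6-chloropyridin-3-yl on a saturated chain carbon bound to an amide-type nitrogen, and the rest of the structure is unchanged. Going by the values given here, with no measured step to guide the direction, only a small shift toward a lower number is expected, one not beyond the scatter. The estimated step is a 1.2-fold lower number from compound 1 to compound 3 (0.08 log units; within the scatter). For compound 3 the expected value is 35000 nM, with an estimated range from 15000 nM to 80000 nM.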

Compound 3, half-maximal inhibitory concentration: 92000 nM
Compound 3: the middle estimate sits 2.6-fold (0.42 log units) below what was measured, and the stated range ends below it.
By their numbers in this assay, from the lowest: compounds 1, 2 and 3 (each within the scatter of the next, the first and the last beyond it).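

In this assay, for the compounds shown here, the swap of 6-chloropyridin-3-yl for 3-chlorophenyl on a saturated chain carbon bound to an amide-type nitrogen gives a 2.2-fold higher number from compound 1 to compound 3 (0.34 log units; beyond the scatter) and is the first single-place change with a measured effect. The step is modest but beyond the usual scatter, so this position does respond to the change, and it moves toward weaker inhibition when the ring nitrogen, counted as a hydrogen-bond acceptor in the leaving group, gives way to an all-carbon ring that keeps the chlorine and the same number of heavy atoms. The information available offers no independent measurement that would explain this shift, so it stands as an observation from one matched pair in one cell assay.

The compounds shown leave open whether the shift belongs to the ring nitrogen itself or to the different placement of the chlorine in the two rings, a question that a 6-chloropyridin-3-yl counterpart such as 4-chlorophenyl could help to separate. They also leave open how this position would respond to a methoxy group or an unsubstituted pyridine ring, or to a longer chain joining the ring to the amide-type nitrogen.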